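Moving the trifluoromethyl group on a diaryl pyridine scaffold

The compounds below may be only part of what the source reports. "The series", "measured", "known", "first", "only" and "open" are said of these compounds alone.

The measured compounds, with their numbers in a functional assay on DU-145 cells (Homo sapiens) for inhibition; a higher number here means a weaker inhibitor, a lower number a stronger inhibitor:
Compound 1, `Oc1cccc(-c2cc(-c3ccccc3F)cc(-c3cccc(O)c3)n2)c1`: 11200 nM
Compound 2, `Oc1cccc(-c2cc(-c3cccc(F)c3)cc(-c3cccc(O)c3)n2)c1`: 23800 nM
Compound 3, `Oc1cccc(-c2cc(-c3ccccc3C(F)(F)F)cc(-c3cccc(O)c3)n2)c1`: 2870 nM

Compound 3 gives the lowest number of the three. The step of a 3.9-fold lower number from compound 1 to compound 3 (0.59 log units; beyond the scatter) separates it from compound 1, and the step of an 8.3-fold lower number from compound 2 to compound 3 (0.92 log units; beyond the scatter) from compound 2, so both measured steps towards compound 3 lie beyond the scatter of this assay.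

Compound 4, `Oc1cccc(-c2cc(-c3cccc(C(F)(F)F)c3)cc(-c3cccc(O)c3)n2)c1`, is not yet measured. It differs from compound 3 in one place: 3-(trifluoromethyl)phenyl in place of 2-(trifluoromethyl)phenyl on an aromatic carbon. The measured step that bears on this change is a 2.1-fold higher number from compound 1 to compound 2 (0.33 log units; beyond the scatter), where the same shift of a substituent from a 2-substituted phenyl to a 3-substituted phenyl on the shared core gave a modest rise in the number. On that basis a step of similar size and direction is expected here, with a 2.1-fold higher number from compound 3 to compound 4 (0.32 log units; beyond the scatter) as the expected step. Compound 4 is therefore estimated at 6000 nM in this assay, within a range from 2500 nM to 15000 nM.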

Compound 4, half-maximal inhibitory concentration: > 50000 nM
Compound 4: no number, only a limit; the forecaster's own chance of this, stated with the estimate: 5%; middle value at least 8.3-fold (0.92 log units) from the limit.
By their numbers in this assay, from the lowest: compound 3; then compound 1; then compound 2. At a limit, above all of these: compound 4.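

In this assay compound 4 gives only a limit of the assay, > 50000 nM, so each step to it is a bound and not a measured size. The position of the trifluoromethyl group on the phenyl ring matters far more than the fluoro pair suggested, with an at least 17-fold higher number from compound 3 to compound 4 (1.24 log units; beyond the scatter), and 3-(trifluoromethyl)phenyl also falls behind 2-fluorophenyl, with an at least 4.4-fold higher number from compound 1 to compound 4 (0.64 log units; beyond the scatter). With an at least 2.1-fold higher number from compound 2 to compound 4 (0.32 log units; beyond the scatter), trifluoromethyl in place of fluoro does not lower the number as it did in 2-(trifluoromethyl)phenyl, so the outcome of that exchange depends on where the group sits: the same change on two cores in this assay, a 3.9-fold lower number (0.59 log units; beyond the scatter) from compound 1 to compound 3 and an at least 2.1-fold higher number (0.32 log units; beyond the scatter) from compound 2 to compound 4, at least 8.1-fold (0.91 log units) apart, beyond the scatter of two such steps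

The compounds shown leave open how far beyond the limit compound 4 lies, and thus the true size of these steps. They also leave open whether a methoxy group, an amine or a carboxylic acid in place of the trifluoromethyl group would show the same dependence on position.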